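Chloro for trifluoromethyl: next member of the series

The compounds below may be only part of what the source reports. "The series", "measured", "known", "first", "only" and "open" are said of these compounds alone.

Among the measured compounds shown here, compound 2 `COC(=O)c1nc(C)n(-c2ccc(C(F)(F)F)cc2)n1` carries the highest of the two numbers measured so far: in a functional assay on NCI-H226 cells (Homo sapiens) for inhibition, read by MTT assay, with a stated time of 72 h (a lower number here means a stronger inhibitor of growth, a higher number a weaker inhibitor of growth), compound 2 gives 16600 nM. Its nearest neighbour is compound 1 `COC(=O)c1nc(C)n(-c2cccc(Br)c2)n1`, which in this assay gives 7350 nM, a smaller number by a margin beyond the usual scatter. For the measured compounds named here, no pair of measured compounds differs in a single place, so nothing is yet known about how one substituent change moves this assay. The next member is compound 3 `COC(=O)c1nc(C)n(-c2ccc(Cl)cc2)n1`, which differs from compound 2 by chloro in place of trifluoromethyl on an aromatic carbon. Going by the values given here, with no measured step to lean on, the change is expected to shift this assay only modestly, with a slight lean towards a lower number. The expected step is a 1.5-fold lower number from compound 2 to compound 3 (0.18 log units; within the scatter). For compound 3 the estimate in this assay is 11000 nM, within a range from 4000 nM to 30000 nM.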

Compound 3, concentration for 50% growth inhibition: 84000 nM
For compound 3 the middle estimate is 7.6-fold (0.88 log units) below the measured one; the whole stated range lies below it.
By their numbers in this assay, from the lowest: compound 1; then compound 2; then compound 3.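

In this assay, chloro in place of trifluoromethyl on an aromatic carbon, para to a large group, gives a 5.1-fold higher number from compound 2 to compound 3 (0.70 log units; beyond the scatter). This first single-place step shows that the assay responds to the substituent at this position, and that this exchange weakens growth inhibition rather than leaving it unchanged. No available measurement accounts for the size of the step.

Still open, as far as these compounds go, is how other groups at this position, such as methoxy, an amine or a nitrile, would read in this assay, and whether any of them would match or improve on trifluoromethyl. Also open, from the compounds shown here alone, is the contribution of the methyl ester on the shared core, for which a carboxylic acid or an amide would provide a single-place comparison.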